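This account rests on a few compounds, and the source may have more. Where it says the series, first, only, none or still open, it means among the compounds named here.

Measured compounds:
compound 1 `Cn1nc2c(=O)n(CC3(O)CCN(Cc4ccc(-c5ccco5)cc4Cl)CC3)cnc2c1-c1ccc(CNS(C)(=O)=O)cc1` — 65.3 nM
compound 2 `Cn1nc2c(=O)n(CC3(O)CCN(Cc4ccc(-c5ccoc5)cc4Cl)CC3)cnc2c1-c1ccc(CN)cc1` — 177 nM
compound 3 `Cn1nc2c(=O)n(CC3(O)CCN(Cc4ccc(-c5ccco5)cc4Cl)CC3)cnc2c1-c1ccc(CNCCO)cc1` — 8.2 nM

In an assay on isolated protein for inhibition of ubiquitin carboxyl-terminal hydrolase 7 (Homo sapiens), with stated times of 30 min and 2 h (on this read-out lower numbers stand for stronger inhibition and higher numbers for weaker inhibition), compound 2 stands highest of the three numbers shown; compound 1 is nearest to it, and compound 3 is furthest. Among the measured compounds shown here, the one step measured within this set, an 8.0-fold lower number from compound 1 to compound 3 (0.90 log units; beyond the scatter), concerns the amine nitrogen and does not touch the place changed here. Compound 4 `Cn1nc2c(=O)n(CC3(O)CCN(Cc4ccc(-c5n[nH]c(=O)o5)cc4Cl)CC3)cnc2c1-c1ccc(CN)cc1` differs from compound 2 as follows: a group of 6 heavy atoms (2 carbon, 2 nitrogen, 2 oxygen; one five-membered aromatic ring with 3 hetero atoms) in place of a group of 5 heavy atoms (4 carbon, 1 oxygen; one five-membered aromatic ring with 1 hetero atom), on an aromatic carbon. For the measured compounds named here, no measured step bears on this change, so the direction is open, and the account expects no step beyond the scatter, with wide uncertainty: a 1.1-fold higher number from compound 2 to compound 4 (0.05 log units; within the scatter). The value expected for compound 4 in this assay is 200 nM, within a range from 50 nM to 800 nM.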

Compound 4, half-maximal inhibitory concentration: 171 nM
Estimate against measurement, compound 4: 1.2-fold (0.07 log units) above; the measured number falls inside the stated range.
By their numbers in this assay, from the lowest: compound 3; then compound 1; then compounds 4 and 2 (each within the scatter of the next).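

In this assay, putting the ring with three hetero atoms, one double bond outside the ring and one hydrogen-bond donor in place of furan-3-yl gives a 1.0-fold lower number from compound 2 to compound 4 (0.01 log units; within the scatter). Among the compounds shown here, this is the first reading at this place, on the aromatic carbon para to a large group, and it shows that these two quite different rings read alike when the amine nitrogen is unsubstituted. Nothing given explains this likeness. The compounds shown leave open whether the swap reads the same with a 2-hydroxyethyl group on the amine nitrogen. They also leave open what a carboxylic acid or a nitrile would do at this place.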